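Cycloheptyl in place of 2-cyclopropylethyl: solubility notes

The source may report more compounds than this note shows. Statements on the series, on what has been measured and on what is new or still open speak of the compounds shown alone.

Compound 1 `O=C(NCc1ccc(-c2noc(CCC3CC3)n2)cc1)[C@H]1NCC[C@@H]1O` is the starting point of this step. In a physicochemical assay for solubility, at pH 7.4 (on this read-out higher numbers stand for higher solubility and lower numbers for lower solubility), compound 1 gives > 50 ug/mL, which is a limit of the assay and not a number. Compound 1 therefore stands at the limit of > 50 ug/mL in this assay, at which 1 of the 3 values shown sits. Two other members of the series carry a seven-carbon chain where compound 1 carries 2-cyclopropylethyl. Compound 2 `CCCCCCCc1nc(-c2ccc([C@@H](NC(=O)[C@H]3NCC[C@@H]3O)C(C)C)cc2)no1` gives 3 ug/mL in this assay. Compound 3 `CCCCCCCc1cc(-c2ccc(CNC(=O)[C@H]3NCC[C@@H]3O)cc2)n[nH]1` gives 3.7 ug/mL, a value within the usual scatter of that of compound 2.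

Compound 4 `O=C(NCc1ccc(-c2noc(C3CCCCCC3)n2)cc1)[C@H]1NCC[C@@H]1O` has not yet been measured. Its difference from compound 1 is cycloheptyl in place of 2-cyclopropylethyl on an aromatic carbon. Within the data shown here, no measured pair in the set differs in this one place alone, so no measured step can be pointed to. The two seven-carbon compounds, compound 2 and compound 3, both sit well below the limit that compound 1 reaches, and a group of seven carbon atoms now enters compound 4 as well. The step is expected to go downward and beyond the scatter, as an at least 4.1-fold lower number from compound 1 to compound 4 (0.61 log units; beyond the scatter). Compound 4 is estimated to give 12 ug/mL in this assay, with an expected range of 4 ug/mL to 45 ug/mL. A reading that again stops at the limit cannot be ruled out.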

Compound 4, solubility: > 50 ug/mL
Compound 4 gave a limit, no number (the forecaster's own chance of this, stated with the estimate: 20%); middle value at least 4.1-fold (0.61 log units) from the limit.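

Compound 1 and compound 4 both stop at a limit of this assay, which is not a number, so no step between them can be read: the limit of > 50 ug/mL in this assay, at which 2 of the 4 values shown sit.

The compounds shown leave open how far past that limit either compound lies, and whether cycloheptyl in place of 2-cyclopropylethyl shifts the read-out at all.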